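Replacing benzyl with chlorothiophene on the sulfonyl sulfur

The compounds below may be only part of what the source reports. "The series", "measured", "known", "first", "only" and "open" are said of these compounds alone.

Among the measured compounds shown here, compound 2 `O=C(NS(=O)(=O)Cc1ccccc1)c1ccc(C(=O)O)nc1` holds the higher of the two numbers so far in an assay on isolated protein (Gallus gallus) for inhibition of transmembrane prolyl 4-hydroxylase (Homo sapiens) (a higher number here means a weaker inhibitor, a lower number a stronger inhibitor), where compound 2 gives 3000 nM; compound 1 `O=C(NS(=O)(=O)c1ccccc1)c1ccc(C(=O)O)nc1` gives 1100 nM in this assay. The change to compound 3 `O=C(NS(=O)(=O)c1ccc(Cl)s1)c1ccc(C(=O)O)nc1` is 5-chlorothiophen-2-yl in place of benzyl on a sulfonyl sulfur. For the measured compounds named here, the one step that bears on it, a 2.7-fold higher number from compound 1 to compound 2 (0.44 log units; beyond the scatter), shows that an aryl group directly on the sulfonyl sulfur gave the lower number, so an aromatic ring returning to that place is expected to bring the number back down by about a 2.5-fold lower number from compound 2 to compound 3 (0.40 log units; beyond the scatter). Compound 3 is therefore estimated at 1200 nM, within 400 nM to 3600 nM.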

Compound 3, half-maximal inhibitory concentration: 2400 nM
Beside the measured number, compound 3's estimate is 2.0-fold (0.30 log units) below it; measured number inside the range.
By their numbers in this assay, from the lowest: compound 1; then compounds 3 and 2 (each within the scatter of the next).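

In this assay, 5-chlorothiophen-2-yl shows that an aromatic ring directly on the sulfonyl sulfur does not by itself keep the number low: against benzyl there is a 1.3-fold lower number from compound 2 to compound 3 (0.10 log units; within the scatter) and against phenyl there is a 2.2-fold higher number from compound 1 to compound 3 (0.34 log units; beyond the scatter). Among these three groups only phenyl stands apart, and compound 2 and compound 3 cannot be ordered. Nothing shown accounts for this.

The compounds shown leave open whether an unsubstituted thiophen-2-yl or a 4-chlorophenyl on the sulfonyl sulfur would stand with compound 1 or with compound 3.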